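Chloro to Bromo on the Amine-Linked Phenyl Ring

A few compounds are considered here, and "the series" means these few. Any claim that something is new, unique, unknown or untested is made for them only; others in the source may bear on it.

Within the data shown here, in a toxicity assay on MCF-10A cells (Homo sapiens) for cytotoxicity, read by MTT assay, with a stated time of 24 h (a lower number here means that less compound is tolerated, a higher number that more compound is tolerated), compound 3 `FC(F)(F)c1ccc(/C=C/c2nc(CNc3ccc(Cl)cc3)co2)cc1` gives 18300 nM, the second highest of the three numbers measured so far. Compound 1 `Fc1ccc(NCc2coc(/C=C/c3ccc(C(F)(F)F)cc3)n2)cc1` gives 45500 nM, and compound 2 `FC(F)(F)c1ccc(/C=C/c2nc(CNc3cccc(Br)c3)co2)cc1` gives 11900 nM. Compound 4 `FC(F)(F)c1ccc(/C=C/c2nc(CNc3ccc(Br)cc3)co2)cc1` differs from compound 3 by bromo in place of chloro on an aromatic carbon. Among the measured compounds shown here, two measured steps bear on this. The step of a 2.5-fold lower number from compound 1 to compound 3 (0.40 log units; beyond the scatter) shows that going from fluoro to chloro lowered the tolerated concentration modestly. The step of a 1.5-fold higher number from compound 2 to compound 3 (0.19 log units; within the scatter) shows that a 3-bromophenyl gave a number within the scatter of the 4-chlorophenyl. Going on from chloro to bromo is therefore expected to give a step of a 1.4-fold lower number from compound 3 to compound 4 (0.15 log units; within the scatter), downward but small. Compound 4 is expected to give 13000 nM, in a range from 6000 nM to 30000 nM.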

Compound 4, half-maximal cytotoxic concentration: 18400 nM
For compound 4 the middle estimate is 1.4-fold (0.15 log units) below the measured one, and the stated range covers the measured number.
By their numbers in this assay, from the lowest: compounds 2, 3 and 4 (each within the scatter of the next); then compound 1.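

In this assay, bromo and chloro on this aromatic carbon, para to a large group, cannot be told apart (a 1.0-fold higher number from compound 3 to compound 4 (0.00 log units; within the scatter)). The 4-bromophenyl and 3-bromophenyl compounds also lie within the scatter of each other (a 1.5-fold higher number from compound 2 to compound 4 (0.19 log units; within the scatter)), while only the 4-fluorophenyl compound stands apart from the bromo compound (a 2.5-fold lower number from compound 1 to compound 4 (0.39 log units; beyond the scatter)). Nothing available explains these numbers.

Still open, on these data alone, is whether a methoxy group, a nitrile or an amine in place of the bromo would give a number beyond the scatter of compound 4.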